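Solubility of a triazole-linked phenol series

A few compounds are considered here, and "the series" means these few. Any claim that something is new, unique, unknown or untested is made for them only; others in the source may bear on it.

Measured so far:
compound 1 `Oc1ccc(-n2cc(-c3ccc4ccccc4n3)nn2)cc1` with 2.2 ug/mL
compound 2 `O=C(O)CCCOc1ccc2nc(-c3cn(-c4ccc(O)c(F)c4)nn3)ccc2c1` with 19.2 ug/mL

This account concerns two measured compounds and one not yet measured. In a physicochemical assay for solubility, read by spectrophotometry, using the shake flask method, with a stated time of 2 days, at pH 6.5 (a higher number here means a more soluble compound, a lower number a less soluble compound), compound 1 gives 2.2 ug/mL, the lower of the two values known. Compound 2, in this assay, gives 19.2 ug/mL, a number well beyond the scatter above that of compound 1; the two differ in more than one place, so nothing more than that gap is taken from the pair.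

Compound 3 `O=C(O)COc1ccc2nc(-c3cn(-c4ccc(O)cc4)nn3)ccc2c1` is compound 1 carrying one change: carboxymethoxy in place of hydrogen on an aromatic carbon. Among the compounds with values here, no measured pair mirrors this single change. Within the data shown here, still, the only other value in hand, that of compound 2 at 19.2 ug/mL, belongs to the one compound built with a side chain ending in carboxylic acid, and it lies higher. For compound 3 the step from compound 1 is expected to be an upward one, a 6.8-fold higher number from compound 1 to compound 3 (0.83 log units; beyond the scatter), beyond the scatter. Compound 3 is estimated at 15 ug/mL, within a range from 4 ug/mL to 50 ug/mL.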

Compound 3, solubility: 365 ug/mL
Compound 3: the middle estimate sits 24-fold (1.39 log units) below what was measured; the measured number lies above the stated range.
By their numbers in this assay, from the lowest: compound 1; then compound 2; then compound 3.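

Within the data shown here, the step from hydrogen to carboxymethoxy gives the first reading of a single change: in this assay, the number moves by a 170-fold higher number from compound 1 to compound 3 (2.22 log units; beyond the scatter) on an aromatic carbon of the six-membered aromatic ring of carbon only, part of a fused or bridged system of two rings. Compound 1 and compound 2 differ in more than one place, so they could tie no gap to this position or to any one group. This pair shows that one substituent at this place, with the rest of compound 1 unchanged, is accompanied by a large step. Nothing in hand bears on why the number moves so far at this position.

From the compounds shown here alone, it remains open whether a simple methoxy, an amine or a longer chain ending in a carboxylic acid, set at this same place on the core of compound 1, would give a step of like size. Going by these compounds, it is also open whether carboxymethoxy on another aromatic carbon of the shared core would do the same.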